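Swapping Nitro for Trifluoromethyl in a Cytotoxicity Series

This account rests on a few compounds, and the source may have more. Where it says the series, first, only, none or still open, it means among the compounds named here.

Of the compounds shown here, three have been tested in a functional assay on B16 cells (Mus musculus) for cytotoxicity, read by MTT assay, with a stated time of 48 h; on this read-out higher numbers stand for weaker inhibition and lower numbers for stronger inhibition. Compound 1 `COc1cccc(Cn2cc(-c3ccc([N+](=O)[O-])cc3)nn2)c1` gives 19100 nM in this assay and is the only one of the three with a measured number. Compound 2 `COc1cccc(Cn2cc(-c3ccc(OC)c(OC)c3OC)nn2)c1` reaches only the limit of the assay, > 100000 nM. Compound 3 `COc1cccc(Cn2cc(-c3ccc4ccccc4c3)nn2)c1` likewise stops at the limit, > 100000 nM. Compound 1 thus stands apart from the limit of > 100000 nM in this assay, at which 2 of the 3 values shown sit.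

Compound 4 `COc1cccc(Cn2cc(-c3ccc(C(F)(F)F)cc3)nn2)c1` has not been measured. It differs from compound 1 in one place: trifluoromethyl in place of nitro on an aromatic carbon. Within the data shown here, no measured pair shows this change, so its effect is not known from these data. The step of a 1.6-fold higher number from compound 1 to compound 4 (0.20 log units; within the scatter) is expected to be small, if anything toward weaker inhibition, close to the scatter. The estimate for compound 4 is 30000 nM, between 8000 nM and 100000 nM.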

Compound 4, half-maximal inhibitory concentration: 17400 nM
For compound 4 the middle estimate is 1.7-fold (0.24 log units) above the measured one; the measured number falls inside the stated range.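

In this assay, among these compounds, the swap of nitro for trifluoromethyl gives a 1.1-fold lower number from compound 1 to compound 4 (0.04 log units; within the scatter) and is the first one-place comparison. At this place on the ring, then, the value does not depend on keeping nitro: a group with 0 hydrogen-bond acceptors, in place of one with 2, gives a number within the scatter. The data shown give no cause for this match.

From the compounds shown here alone, it remains open whether an amine, a carboxylic acid or a nitrile at this place would give a similar number. Nor do the compounds shown tell what a hydroxyl in place of the methoxy group of the shared core would do.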